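The compounds below may be only part of what the source reports. "The series", "measured", "known", "first", "only" and "open" are said of these compounds alone.

Compound 1, `CNc1nc(NCc2ccc(NC(=O)c3ccncc3)cc2)c2ccccc2n1`, is one of three measured analogues built on a shared core. In a functional assay on HCT-116 cells (Homo sapiens) for inhibition, read by luminescence and resazurin assay, with a stated time of 3 days (a higher number here means a weaker inhibitor, a lower number a stronger inhibitor), compound 1 gives only a limit, > 20000 nM, so no number stands for it. Compound 2, `CN(C)c1nc(NCc2ccc(NC(=O)c3ccncc3)cc2)c2ccccc2n1`, gives 15000 nM in this assay. Compound 3, `CN1CCN(c2nc(NCc3ccc(NC(=O)c4ccncc4)cc3)c3ccccc3n2)CC1`, gives a limit, > 20000 nM, in this assay. The three steps among them, an at least 1.3-fold lower number from compound 1 to compound 2 (0.12 log units; that floor lies within the scatter), a step that the two limits leave unreadable from compound 1 to compound 3 and an at least 1.3-fold higher number from compound 2 to compound 3 (0.12 log units; that floor lies within the scatter), all alter the group attached to the core, and the limit of > 20000 nM in this assay, at which 2 of the 3 values shown sit, leaves their sizes as floors or unreadable. Compound 4, `CNc1nc(NCc2ccc(NC(=O)c3ccc(F)cc3)cc2)c2ccccc2n1`, differs from compound 1 at a different place: 4-fluorophenyl in place of pyridin-4-yl on a carbonyl carbon. Within the data shown here, none of the measured steps touches that part of the molecule, so none of them bears on this change; what they show is only that compound 1 sits at the limit of this assay. With no guide beyond that starting point, the step that the limit leaves unreadable from compound 1 to compound 4 is expected to be none that can be read beyond the scatter. Compound 4 is therefore estimated at 25000 nM in this assay, within 8000 nM to 80000 nM, and most likely to be returned again as a limit rather than a number.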

Compound 4, half-maximal inhibitory concentration: 1600 nM
For compound 4 the middle estimate is 16-fold (1.19 log units) above the measured one, outside the stated range (below it).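

Putting 4-fluorophenyl in place of pyridin-4-yl on a carbonyl carbon gives an at least 12-fold lower number from compound 1 to compound 4 (1.09 log units; beyond the scatter) in this assay, so this end of the molecule can move the read-out beyond the scatter, whereas the floors readable for the earlier changes to the group on the shared core stayed within it. Unlike compound 1, compound 4 gives a measured number, 1600 nM, so this series now has a value that can be compared with its close analogues. The true size of the step remains unknown, because compound 1 stands at a limit and not at a number: the limit of > 20000 nM in this assay, at which 2 of the 4 values shown sit.

The change removes the ring nitrogen and adds fluorine in a single step, so the compounds shown do not separate the two, and it remains open where plain phenyl or 4-chlorophenyl would fall on the same carbonyl carbon. Going by these compounds, it is also open whether 4-fluorophenyl would have a similar effect with dimethylamino or 4-methylpiperazin-1-yl in place of methylamino on the shared core.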